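A few compounds are considered here, and "the series" means these few. Any claim that something is new, unique, unknown or untested is made for them only; others in the source may bear on it.

Measured compounds:
- Compound 1 `O=C(O)C12CCC(C(=O)N3CC[C@](c4ccc(C(F)(C(F)(F)F)C(F)(F)F)cc4)(S(=O)(=O)c4ccc(F)cc4)C3)(CC1)C2`: "not determined" (no result reported) in an ADME assay on microsomes from liver (Mus musculus) for metabolic stability, with a stated time of 10 min; on this read-out lower numbers stand for a less stable compound and higher numbers for a more stable compound
- Compound 2 `O=C(N1CC[C@](c2ccc(C(F)(C(F)(F)F)C(F)(F)F)cc2)(S(=O)(=O)c2ccc(F)cc2)C1)C1(F)CCS(=O)(=O)CC1`: 90% in this assay
- Compound 3 `O=C(N1CC[C@](c2ccc(C(F)(C(F)(F)F)C(F)(F)F)cc2)(S(=O)(=O)c2ccc(F)cc2)C1)C1(O)CCS(=O)(=O)CC1`: 90% in this assay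

Compound 1 stands nowhere on the numbers shown, since no value was reported for it in this assay. Compound 4 `O=C(N1CC[C@](c2ccc(C(F)(C(F)(F)F)C(F)(F)F)cc2)(S(=O)(=O)c2ccc(F)cc2)C1)C1(CO)CCS(=O)(=O)CC1` arises from compound 1 through the following change: a group of 10 heavy atoms (6 carbon, 3 oxygen, 1 sulfur; one six-membered non-aromatic ring with 1 hetero atom) in place of a group of 10 heavy atoms (8 carbon, 2 oxygen; 2 five-membered non-aromatic rings of carbon only), on a carbonyl carbon. Within the data shown here, no measured step covers this exchange directly. Among the measured compounds shown here, the one step that was measured, no change at the digits printed from compound 2 to compound 3 (within the scatter), exchanges two small groups on the same six-membered ring that enters in compound 4, and it stayed within the scatter. Compound 4 carries that ring with a hydroxymethyl group where compound 2 carries fluoro and compound 3 carries hydroxy, and both of those gave the same high reading. Compound 1 gives no number to step from, so the expectation for compound 4 rests on compounds 2 and 3 alone. Compound 4 is therefore expected to give about 85% in this assay, with an estimated range from 70% to 95%.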

Compound 4, percent of the compound remaining: 31%
Beside the measured number, compound 4's estimate is 54 percentage points above it, and the stated range ends above it.
By their numbers in this assay, from the lowest: compound 4; then compounds 2 and 3 (each within the scatter of the next).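

In this assay, the group on the saturated ring carbon proves able to change the reading sharply, even though the six-membered ring itself stays the same: hydroxymethyl in place of hydroxy gives a number 59 percentage points lower from compound 3 to compound 4 (beyond the scatter), and hydroxymethyl in place of fluoro gives a number 59 percentage points lower from compound 2 to compound 4 (beyond the scatter). The earlier exchange, with no change at the digits printed from compound 2 to compound 3 (within the scatter), showed only that hydroxy and fluoro read alike at this carbon, and that agreement does not carry over to hydroxymethyl. Nothing shown bears on the reason for the fall.

The compounds shown leave open whether the fall follows the extra carbon or the hydroxy group on it, which a methyl, a methoxymethyl, a hydroxyethyl chain, an amine or a carboxylic acid at this carbon could help separate. Among these compounds, compound 1 has no number in this read-out, so the exchange from its ring group to the one in compound 4 cannot be read.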